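The source may report more compounds than this note shows. Statements on the series, on what has been measured and on what is new or still open speak of the compounds shown alone.

Compound 1 `COc1ccc(-c2sc(C(=O)O)cc2-c2cc(OC)c(OC)c(OC)c2)cc1OCc1ccccc1` was tested in a functional assay on KB cells (Homo sapiens) for antiproliferative activity, read by MTT assay, with a stated time of 72 h (on this read-out higher numbers stand for weaker inhibition and lower numbers for stronger inhibition), and reached only a limit there, > 100000 nM. Compound 2 `COc1ccc(-c2sc(C(=O)O)cc2-c2cc(OC)c(OC)c(OC)c2)cc1O`, which carries hydrogen in place of benzyl on an oxygen on an aromatic ring, gives 11200 nM in this assay. The step of an at least 8.9-fold lower number from compound 1 to compound 2 (0.95 log units; beyond the scatter) therefore shows that removing the benzyl group strengthened inhibition. Compound 3 `COc1ccc(-c2cc(C(=O)O)sc2-c2cc(OC)c(OC)c(OC)c2)cc1OCc1ccccc1` is built from the same atoms as compound 1 joined differently; the difference between the two cores is not broken down here. Compound 3 also sits at a limit in this assay, > 100000 nM, which is the limit of > 100000 nM in this assay, at which 2 of the 3 values shown sit. Compound 4 `COc1ccc(-c2cc(C(=O)O)sc2-c2cc(OC)c(OC)c(OC)c2)cc1O` differs from compound 3 by hydrogen in place of benzyl on an oxygen on an aromatic ring, the same change at the same place. Compound 4 is expected to fall by an at least 6.6-fold lower number from compound 3 to compound 4 (0.82 log units; beyond the scatter), a step resting on compound 2 at 11200 nM and on an at least 8.9-fold lower number from compound 1 to compound 2 (0.95 log units; beyond the scatter). Compound 4 is estimated at 15000 nM, between 4000 nM and 100000 nM.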

Compound 4, half-maximal inhibitory concentration: 21800 nM
Compound 4: middle estimate off by 1.5-fold (0.16 log units), on the low side; measured number inside the range.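

On both cores, replacing benzyl with hydrogen on the oxygen strengthens inhibition in this assay, and the new case gives an at least 4.5-fold lower number from compound 3 to compound 4 (0.66 log units; beyond the scatter). The change therefore carries over from the core of compound 1 to the core of compound 3 in direction, but the comparison of the two steps stays open in size: the same change on two cores in this assay, an at least 8.9-fold lower number (0.95 log units; beyond the scatter) from compound 1 to compound 2 and an at least 4.5-fold lower number (0.66 log units; beyond the scatter) from compound 3 to compound 4; the limit leaves it open whether they differ Two cores also cannot show that the change would work on a third, and the true size of each step stays unknown, since both benzyl compounds reach only a limit: the limit of > 100000 nM in this assay, at which 2 of the 4 values shown sit.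

The compounds shown leave open how an ethyl group on that oxygen, or an amine in place of the hydroxy, would read in this assay. They also leave open what an amide in place of the carboxylic acid would do.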